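Extending the hydroxyalkyl amide of compound 3

This account rests on a few compounds, and the source may have more. Where it says the series, first, only, none or still open, it means among the compounds named here.

Of the compounds shown here, three sharing one core have been measured in an assay on isolated protein for inhibition of alkaline phosphatase, tissue-nonspecific isozyme (Homo sapiens); on this read-out lower numbers stand for stronger inhibition and higher numbers for weaker inhibition. Compound 1 `O=C(c1cc(-c2ccc(Cl)cc2Cl)n[nH]1)N1CCCCCC1` gives 1450 nM. Compound 2 `O=C(NCCO)c1cc(-c2cc(F)c(Cl)cc2Cl)n[nH]1` gives 100 nM. Compound 3 `CN(C)C(=O)c1cc(-c2cc(F)c(Cl)cc2Cl)n[nH]1` gives 324 nM, which places it second highest of the three numbers: its nearest neighbour is compound 2 with the lower number, and compound 1 stands furthest away with the higher one. Going by the values given here, the only step between measured compounds that differ in a single place runs a 3.2-fold higher number from compound 2 to compound 3 (0.51 log units; beyond the scatter), a modest but real loss on going from the (2-hydroxyethyl)amino amide to the dimethylamino amide.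

Compound 4 `O=C(NCCCO)c1cc(-c2cc(F)c(Cl)cc2Cl)n[nH]1` differs from compound 3 in one place: (3-hydroxypropyl)amino in place of dimethylamino on a carbonyl carbon. The entering group is a close relative of the (2-hydroxyethyl)amino group of compound 2, so the measured step from compound 2 to compound 3 is the one that bears on this change, and it is expected to be largely undone. Compound 4 is therefore expected to settle close to compound 2, whose value is 100 nM, with some allowance for the longer chain being untested. For compound 4 the expected step is a 2.3-fold lower number from compound 3 to compound 4 (0.36 log units; beyond the scatter). The estimate for compound 4 is 140 nM, with a range from 50 nM to 400 nM.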

Compound 4, half-maximal inhibitory concentration: 56 nM
Compound 4: the middle estimate sits 2.5-fold (0.40 log units) above what was measured; the measured number falls inside the stated range.
By their numbers in this assay, from the lowest: compounds 4 and 2 (each within the scatter of the next); then compound 3; then compound 1.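

On the carbonyl carbon of the shared core, (3-hydroxypropyl)amino in place of dimethylamino gives, in this assay, a 5.8-fold lower number from compound 3 to compound 4 (0.76 log units; beyond the scatter), so a second hydroxyalkyl amide now stands apart from the dimethylamino amide, where previously only a 3.2-fold higher number from compound 2 to compound 3 (0.51 log units; beyond the scatter) pointed that way. The chain also tolerates extension at this position: the step between the two hydroxyalkyl amides, a 1.8-fold lower number from compound 2 to compound 4 (0.25 log units; within the scatter), stays within the scatter, so compound 2 and compound 4 cannot be told apart in this read-out and chain length shows no effect across these two. Nothing available here bears on why the hydroxyalkyl amides and the dimethylamino amide differ.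

The compounds shown do not separate the contribution of the hydroxy group from that of the amide hydrogen, which a plain propylamino group or a (3-methoxypropyl)amino group on the same carbonyl carbon could do. Also open, from the compounds shown here alone, is how far this tolerance extends, whether to a longer hydroxyalkyl chain or to an amine or a carboxylic acid in place of the hydroxy group.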